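The source may hold more compounds than are shown below. What is called first, only, known or untested is meant among the compounds shown, and "the series" means these compounds.

Measured compounds:
compound 1 `CC[C@@H]1CN(c2scnc2-c2nc3ccccc3[nH]2)CCN1C(=O)Cn1cnc2cccnc21` gives 851 nM in an assay on blood for inhibition of C-X-C chemokine receptor type 3 (Homo sapiens), with a stated time of 30 min; on this read-out lower numbers stand for stronger inhibition and higher numbers for weaker inhibition;
compound 2 `CCOc1ncc(-c2nc(C(F)(F)F)sc2N2CCN(C(=O)Cn3cnc4cccnc43)[C@H](C)C2)cn1` gives 48 nM in this assay;
compound 3 `CCOc1ncc(-c2nc(C(F)(F)F)sc2N2CCN(C(=O)Cn3cnc4ccccc43)[C@H](C)C2)cn1` gives 192 nM in this assay.

Compound 3 stands second highest of the three numbers; its nearest neighbour is compound 2 and its furthest is compound 1. The change from compound 3 to compound 4 `CCOc1ncc(-c2nc(C(F)(F)F)sc2N2CCN(C(=O)Cn3ccc4cccnc43)[C@H](C)C2)cn1` is a group of 9 heavy atoms (7 carbon, 2 nitrogen; one five-membered aromatic ring with 1 hetero atom, one six-membered aromatic ring with 1 hetero atom) in place of a group of 9 heavy atoms (7 carbon, 2 nitrogen; one five-membered aromatic ring with 2 hetero atoms, one six-membered aromatic ring of carbon only), on a saturated chain carbon bound to a carbonyl carbon. Among the measured compounds shown here, the one measured step at this same place, a 4.0-fold higher number from compound 2 to compound 3 (0.60 log units; beyond the scatter), swapped a ring nitrogen for a ring carbon, whereas here one ring nitrogen moves from the five-membered to the six-membered ring and no measured step shows such a move. The expected step is therefore small, a 1.0-fold higher number from compound 3 to compound 4 (0.02 log units; within the scatter), perhaps recovering part of what compound 2 showed. Compound 4 is estimated at 200 nM, within 70 nM to 600 nM.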

Compound 4, half-maximal inhibitory concentration: 47 nM
The estimate for compound 4 lay 4.3-fold (0.63 log units) above the measured number, and the stated range ends above it.
By their numbers in this assay, from the lowest: compounds 4 and 2 (each within the scatter of the next); then compound 3; then compound 1.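

With the same atoms joined differently, moving one ring nitrogen from the five-membered to the six-membered ring gives a 4.1-fold lower number from compound 3 to compound 4 (0.61 log units; beyond the scatter), so this place responds to where the nitrogen sits and not just to how many there are. Compound 2 and compound 4 both have a nitrogen in the six-membered ring, and a 1.0-fold lower number from compound 2 to compound 4 (0.01 log units; within the scatter) shows that the extra nitrogen in the five-membered ring of compound 2 adds nothing that can be read here. Nothing available explains the shift. From the compounds shown here alone, it remains open how a 1H-indol-1-yl group, with carbon only in its six-membered ring, would compare at this place.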